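A few compounds are considered here, and "the series" means these few. Any claim that something is new, unique, unknown or untested is made for them only; others in the source may bear on it.

Measured so far:
compound 1 `O=C(COc1ccc(C(=O)/C=C/c2ccccc2Br)cc1)N[C@H]1CCOC1=O` – 3540 nM
compound 2 `CC(C)(C)c1ccc(/C=C/C(=O)c2ccc(OCC(=O)N[C@H]3CCOC3=O)cc2)cc1` – 6570 nM

In a functional assay on DU-145 cells (Homo sapiens) for antiproliferative activity, read by MTT assay, with a stated time of 72 h (a lower number here means a stronger inhibitor, a higher number a weaker inhibitor), compound 2 gives the highest of the two numbers, nearest to compound 1, the step of a 1.9-fold higher number from compound 1 to compound 2 (0.27 log units; within the scatter) lying within the scatter. Compound 3 `O=C(COc1ccc(C(=O)/C=C/c2cccc(Br)c2)cc1)N[C@H]1CCOC1=O` differs from compound 2 by 3-bromophenyl in place of 4-(tert-butyl)phenyl on a double-bonded chain carbon bound to a double-bonded chain carbon. Among the measured compounds shown here, the only step recorded, a 1.9-fold higher number from compound 1 to compound 2 (0.27 log units; within the scatter), exchanged a bromophenyl for the tert-butylphenyl without moving beyond the scatter, so the reverse kind of exchange is expected to stay within the scatter too. For compound 3 the estimate in this assay is 4200 nM, within 1500 nM to 12000 nM, an expected step of a 1.6-fold lower number from compound 2 to compound 3 (0.19 log units; within the scatter).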

Compound 3, half-maximal inhibitory concentration: 9800 nM
For compound 3 the middle estimate is 2.3-fold (0.37 log units) below the measured one; the measured number falls inside the stated range.
By their numbers in this assay, from the lowest: compounds 1, 2 and 3 (each within the scatter of the next, the first and the last beyond it).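

In this assay, among the compounds shown here, the exchange of 2-bromophenyl for 3-bromophenyl gives a 2.8-fold higher number from compound 1 to compound 3 (0.44 log units; beyond the scatter) and is the only step so far beyond the scatter, so at this position the placing of the bromine on the phenyl ring has a modest bearing on the number. The exchange of 4-(tert-butyl)phenyl for 3-bromophenyl gives a 1.5-fold higher number from compound 2 to compound 3 (0.17 log units; within the scatter) and does not separate the two groups. No measurement at hand explains either step.

Still open, going by these compounds, is how 4-bromophenyl compares with the two bromophenyl isomers. Also open, on these data alone, is whether a methoxyphenyl or an aminophenyl at this position would fall outside the present range.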